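The source may report more compounds than this note shows. Statements on the series, on what has been measured and on what is new or still open speak of the compounds shown alone.

- compound 1 `C[C@H]1O[C@@H](n2cnc3c(N)nc(I)nc32)[C@H](O)[C@@H]1O` gives 110000 nM
- compound 2 `C[C@H]1O[C@@H](n2cnc3c(N)nc(C#N)nc32)[C@H](O)[C@@H]1O` gives 177000 nM

In an ADME assay on L6 cells (Rattus norvegicus) for cytotoxicity (a lower number here means a stronger inhibitor, a higher number a weaker inhibitor), compound 1 gives 110000 nM and sits within the scatter of compound 2. Compound 3 `CNc1nc(I)nc2c1ncn2[C@@H]1O[C@H](C)[C@@H](O)[C@H]1O` has methyl in place of hydrogen on a nitrogen on an aromatic ring, amino to methylamino: methyl in place of hydrogen on a nitrogen on an aromatic ring. For the measured compounds named here, no measured step changes that nitrogen. Going by the values given here, the only step available, a 1.6-fold higher number from compound 1 to compound 2 (0.21 log units; within the scatter), concerns a different group, so it offers weak guidance. No change beyond the scatter is therefore expected in this assay. The expected step is a 1.2-fold lower number from compound 1 to compound 3 (0.09 log units; within the scatter). For compound 3 the estimated value is 90000 nM, with an expected range from 35000 nM to 230000 nM.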

Compound 3, half-maximal inhibitory concentration: 137000 nM
The estimate for compound 3 lay 1.5-fold (0.18 log units) below the measured number, within the range that was stated.
By their numbers in this assay, from the lowest: compounds 1, 3 and 2 (each within the scatter of the next).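

Methyl in place of hydrogen on a nitrogen on an aromatic ring, amino to methylamino, gives a 1.2-fold higher number from compound 1 to compound 3 (0.10 log units; within the scatter) in this assay. For the compounds shown here, this is the first measured change at that nitrogen, as the earlier step concerned the iodo group, and it shows that in this iodo compound, the methyl leaves the cytotoxicity reading indistinguishable from the amino parent. No measurement at hand offers a reason for this result.

Going by these compounds, whether an ethyl group, a longer chain or a second methyl on that nitrogen would also stay within the scatter remains open. So does whether methylamino behaves the same way with the nitrile of compound 2.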